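Replacing Fluoro with (tert-Butoxycarbonyl)amino on the Aromatic Ring

This account rests on a few compounds, and the source may have more. Where it says the series, first, only, none or still open, it means among the compounds named here.

In a functional assay on MDA-MB-231 cells (Homo sapiens) for antiproliferative activity, read by MTT assay, with a stated time of 72 h (on this read-out higher numbers stand for weaker inhibition and lower numbers for stronger inhibition), compound 1 `O=C(CCc1cccc2c1B(O)OC2)NCc1ccccc1`, which carries benzyl on the amide nitrogen, reports only a limit, > 100000 nM. With 4-fluorophenyl there instead, compound 2 `O=C(CCc1cccc2c1B(O)OC2)Nc1ccc(F)cc1` gives 440 nM, the lower of the two numbers in this set, while compound 3 `O=C(CCc1cccc2c1B(O)OC2)Nc1ccc(Cl)cc1`, with 4-chlorophenyl, gives 3600 nM. Changing the group on the nitrogen produced large steps, an at least 220-fold lower number from compound 1 to compound 2 (2.35 log units; beyond the scatter) and an at least 27-fold lower number from compound 1 to compound 3 (1.44 log units; beyond the scatter), but these concern a different place from the next change.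

Compound 4 `CC(C)(C)OC(=O)Nc1ccc(NC(=O)CCc2cccc3c2B(O)OC3)cc1` has (tert-butoxycarbonyl)amino in place of fluoro on an aromatic carbon, para to a large group: (tert-butoxycarbonyl)amino in place of fluoro on an aromatic carbon. Going by the values given here, the only change measured at that carbon is an 8.2-fold higher number from compound 2 to compound 3 (0.91 log units; beyond the scatter), a modest step beyond the scatter. Among the compounds with values here, no measured compound carries the entering group, so this guidance is indirect. A modest step toward a higher number in this assay is therefore expected, and the estimated change is a 5.7-fold higher number from compound 2 to compound 4 (0.75 log units; beyond the scatter). For compound 4 the estimated value is 2500 nM, with an expected range of 400 nM to 20000 nM.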

Compound 4, half-maximal inhibitory concentration: 29000 nM
Estimate against measurement, compound 4: 12-fold (1.06 log units) below; the whole stated range lies below it.
By their numbers in this assay, from the lowest: compound 2; then compound 3; then compound 4. At a limit, above all of these: compound 1.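

In this assay, this aromatic carbon, para to a large group, proves far more sensitive than the exchange of fluoro for chloro alone could show: the new group gives a 66-fold higher number from compound 2 to compound 4 (1.82 log units; beyond the scatter), and measured against the chloro compound it gives an 8.1-fold higher number from compound 3 to compound 4 (0.91 log units; beyond the scatter). Across these three compounds the numbers rise in the order fluoro, chloro, (tert-butoxycarbonyl)amino, and none of the three goes against that order. Compound 4 nevertheless still gives a number, and compound 1 alone remains a limit rather than a number: the limit of > 100000 nM in this assay, at which 1 of the 4 values shown sits.

From the compounds shown here alone, it remains open whether a free amine or an acetamide on this carbon would stand nearer compound 2 or nearer compound 4. The compounds shown also do not separate the part played by the tert-butyl group from that of the remaining carbonyl and nitrogen.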